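The source may hold more compounds than are shown below. What is called first, only, known or untested is meant among the compounds shown, and "the series" means these compounds.

Compound 1 `Cc1nn(-c2ncnc3nc[nH]c23)c2c1C(OCCc1ccccc1)CC(=O)N2`: in a functional assay on HEK293 cells for agonist activity at G-protein coupled receptor 39 (Homo sapiens), read by scintillation proximity assay and inositol phosphate accumulation, with a stated time of 75 min, in the presence of a further agent that is not named here (on this read-out higher numbers stand for an effect only at larger amounts of compound and lower numbers for an effect already at smaller amounts), compound 1 gives 3 nM.
Compound 2 `Cc1nn(-c2ncnc3nc[nH]c23)c2c1C(OCc1ccccc1Cl)CC(=O)N2`: in this assay compound 2 gives 2 nM.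
Compound 3 `Cc1nn(-c2ncnc3nc[nH]c23)c2c1C(OCCn1cccn1)CC(=O)N2`: in this assay compound 3 gives 16 nM.

Compound 3 carries the highest number of the three: the steps of a 5.3-fold higher number from compound 1 to compound 3 (0.73 log units; beyond the scatter) and an 8.0-fold higher number from compound 2 to compound 3 (0.90 log units; beyond the scatter) both lie beyond the scatter, whereas a 1.5-fold lower number from compound 1 to compound 2 (0.18 log units; within the scatter) lies within it. Compound 4 `COc1ccc(CCOC2CC(=O)Nc3c2c(C)nn3-c2ncnc3nc[nH]c23)cc1` differs from compound 3 by 4-methoxyphenyl in place of 1H-pyrazol-1-yl on a saturated chain carbon, two bonds along the chain from an oxygen on a saturated carbon. The step that bears on this change is a 5.3-fold higher number from compound 1 to compound 3 (0.73 log units; beyond the scatter), which exchanges phenyl for 1H-pyrazol-1-yl at the same place; compound 4 largely reverses that exchange, with a 4-methoxyphenyl entering instead of plain phenyl. A modest move to a lower number, roughly back to where compound 1 stands, is therefore expected. Compound 4 is estimated to give 4 nM, within a range of 1.5 nM to 12 nM. The expected step is then a 4.0-fold lower number from compound 3 to compound 4 (0.60 log units; beyond the scatter).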

Compound 4, half-maximal effective concentration: 2 nM
Beside the measured number, compound 4's estimate is 2.0-fold (0.30 log units) above it, within the range that was stated.
By their numbers in this assay, from the lowest: compounds 2, 4 and 1 (each within the scatter of the next); then compound 3.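

In this assay, 4-methoxyphenyl at this place undoes the loss seen with 1H-pyrazol-1-yl, giving an 8.0-fold lower number from compound 3 to compound 4 (0.90 log units; beyond the scatter). Adding methoxy to the phenyl ring of compound 1 is tolerated, with a 1.5-fold lower number from compound 1 to compound 4 (0.18 log units; within the scatter), and 4-methoxybenzyl matches 2-chlorophenyl, with no change at the digits printed from compound 2 to compound 4 (within the scatter). No measurement here explains these results. As far as these compounds go, it remains open whether an amine or a carboxylic acid in place of the methoxy would be tolerated as well. A longer chain between the oxygen and the 4-methoxyphenyl is also untested in the compounds shown.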